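The source may hold more compounds than are shown below. What is called first, only, known or untested is meant among the compounds shown, and "the series" means these compounds.

In a functional assay on CCRF-CEM cells (Homo sapiens) for antiproliferative activity, read by resazurin assay, with a stated time of 72 h (a higher number here means a weaker inhibitor, a lower number a stronger inhibitor), the three measured compounds give these values:

Compound 1 `COc1ccc(-c2nc3c(c(-c4ccccc4)nn3-c3ccccc3)c(-c3ccc(O)cc3)c2C#N)cc1` gives 6700 nM.
Compound 2 `N#Cc1c(-c2ccc(F)cc2)nc2c(c(-c3ccccc3)nn2-c2ccccc2)c1-c1ccc(O)cc1` gives only a limit, > 25000 nM.
Compound 3 `N#Cc1c(-c2ccc(Cl)cc2)nc2c(c(-c3ccccc3)nn2-c2ccccc2)c1-c1ccc(O)cc1` gives 43100 nM.

Compound 2 therefore stands at the limit of this assay (the limit of > 25000 nM in this assay, at which 1 of the 3 values shown sits), so no number is known for it, and it can only be placed as weaker than compound 1. The new compound, compound 4 `N#Cc1c(-c2ccccc2)nc2c(c(-c3ccccc3)nn2-c2ccccc2)c1-c1ccc(O)cc1`, differs from compound 2 in one place: hydrogen in place of fluoro on an aromatic carbon. The measured steps that bear on this position are an at least 3.7-fold higher number from compound 1 to compound 2 (0.57 log units; beyond the scatter) and a 6.4-fold higher number from compound 1 to compound 3 (0.81 log units; beyond the scatter): both halogens gave weaker inhibitors than the methoxy group. The step that the limit leaves unreadable from compound 2 to compound 3 cannot be read. Among the compounds with values here, none of the measured steps tests a bare hydrogen at this place, so the direction is open. Compound 4 is expected to fall somewhere between compound 1 and the limit, with a step of an at least 1.6-fold lower number from compound 2 to compound 4 (0.22 log units; that floor lies within the scatter) that cannot be sized from a limit. Compound 4 is estimated at 15000 nM, within a range of 3000 nM to 60000 nM.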

Compound 4, half-maximal inhibitory concentration: 33400 nM
The estimate for compound 4 lay 2.2-fold (0.35 log units) below the measured number; the measured number falls inside the stated range.
By their numbers in this assay, from the lowest: compound 1; then compounds 4 and 3 (each within the scatter of the next).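

With hydrogen on this ring carbon the result is a 1.3-fold lower number from compound 3 to compound 4 (0.11 log units; within the scatter), so in this assay a bare phenyl and a 4-chlorophenyl cannot be told apart. Hydrogen also gives a 5.0-fold higher number from compound 1 to compound 4 (0.70 log units; beyond the scatter), so among the groups with a readable number here, methoxy alone stands apart, and the weaker result of compound 3 needs no special penalty from chloro to account for it. Steps involving compound 2 cannot be read, because it carries only a limit: the limit of > 25000 nM in this assay, at which 1 of the 4 values shown sits.

The compounds shown leave open whether another group at this place, such as an amine, a hydroxyl or a longer ethoxy chain, would match or go beyond compound 1. They also leave open how changes elsewhere on the shared core would act on these values.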